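Swapping the Aryl Group on the Sulfonyl Sulfur

The compounds below may be only part of what the source reports. "The series", "measured", "known", "first", "only" and "open" are said of these compounds alone.

Measured so far in an assay on cells for inhibition of HSP60/HSP10 (Homo sapiens), with a stated time of 60 min; a lower number here means a stronger inhibitor, a higher number a weaker inhibitor:
Compound 1, `O=S(=O)(Nc1ccc(-c2nc3ccccc3o2)cc1)c1cccc(O)c1`: 62000 nM
Compound 2, `O=S(=O)(Nc1ccc(-c2nc3ccccc3o2)cc1)c1cccc(Cl)c1`: 54000 nM
Compound 3, `C=Cc1ccc(S(=O)(=O)Nc2ccc(-c3nc4ccccc4o3)cc2)cc1`: here compound 3 reached only the assay limit, > 100000 nM

Compound 3 therefore stands at the weak end of the numbers shown, with a limit rather than a number; it is the one of these three at the limit of > 100000 nM in this assay, at which 1 of the 3 values shown sits. The step from compound 1 to compound 2, a chloro in place of a hydroxy, gave a 1.1-fold lower number from compound 1 to compound 2 (0.06 log units; within the scatter). The two steps that lead to compound 3 both change the aryl on the sulfonyl sulfur: an at least 1.6-fold higher number from compound 1 to compound 3 (0.20 log units; that floor lies within the scatter) and an at least 1.8-fold higher number from compound 2 to compound 3 (0.26 log units; that floor lies within the scatter), each only a floor and each within the scatter.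

Compound 4, `O=S(=O)(Nc1ccc(-c2nc3ccccc3o2)cc1)c1ccc(Cl)c(Cl)c1`, differs from compound 3 as follows: 3,4-dichlorophenyl in place of 4-vinylphenyl on a sulfonyl sulfur. Both earlier changes on the sulfonyl sulfur moved the number by no more than the scatter, so for compound 4 a return toward the values of compound 1 and compound 2 is expected, and the step of an at least 2.0-fold lower number from compound 3 to compound 4 (0.30 log units; that floor lies within the scatter) is expected to be small in this assay. Compound 4 is estimated at 50000 nM, within 20000 nM to 150000 nM.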

Compound 4, half-maximal inhibitory concentration: 25000 nM
For compound 4 the middle estimate is 2.0-fold (0.30 log units) above the measured one; the measured number falls inside the stated range.
By their numbers in this assay, from the lowest: compound 4; then compounds 2 and 1 (each within the scatter of the next). At a limit, above all of these: compound 3.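

In this assay, the aryl group on the sulfonyl sulfur now gives steps beyond the scatter, which the swap of hydroxy for chloro had not: one more chloro on the aryl group gives a 2.2-fold lower number from compound 2 to compound 4 (0.33 log units; beyond the scatter), and 3,4-dichlorophenyl in place of 3-hydroxyphenyl gives a 2.5-fold lower number from compound 1 to compound 4 (0.39 log units; beyond the scatter). Replacing 4-vinylphenyl with 3,4-dichlorophenyl gives an at least 4.0-fold lower number from compound 3 to compound 4 (0.60 log units; beyond the scatter), and this step is only a floor. Compound 3 remains a limit and not a number: the limit of > 100000 nM in this assay, at which 1 of the 4 values shown sits.

The compounds shown leave open whether a bromo, a trifluoromethyl or a methoxy group in place of the chloro groups would move the number the same way. They also leave open what an amine or a carboxylic acid on this aryl ring would do.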